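Methoxy on the Benzyl Ring in Two Coumarin Amides

A few compounds are considered here, and "the series" means these few. Any claim that something is new, unique, unknown or untested is made for them only; others in the source may bear on it.

Three compounds with a shared coumarin amide core were examined in a functional assay on SK-BR-3 cells (Homo sapiens) for antiproliferative activity; on this read-out higher numbers stand for weaker inhibition and lower numbers for stronger inhibition. Compound 1 `COc1cccc(Cc2ccc3cc(NC(=O)c4ccc(O)c(CC=C(C)C)c4)c(=O)oc3c2C)c1` gives 14800 nM in this assay. Compound 2 `COc1ccc(Cc2ccc3cc(NC(=O)c4ccc(O)c(CC=C(C)C)c4)c(=O)oc3c2C)cc1OC` reaches only the limit of this assay, > 100000 nM, which is a limit and not a number. Compound 3 `COc1cccc(-c2cc(C(=O)Nc3cc4ccc(Cc5ccccc5)c(C)c4oc3=O)ccc2OC)c1` gives 4090 nM, the lowest number of the two that were read; the number of compound 1 is higher. How the cores of compound 3 and compound 1 differ is not broken down here.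

The change from compound 1 to compound 2 is methoxy in place of hydrogen on an aromatic carbon, and in this assay it produced an at least 6.7-fold higher number from compound 1 to compound 2 (0.82 log units; beyond the scatter), a step that rests on (the limit of > 100000 nM in this assay, at which 1 of the 3 values shown sits). Compound 4 `COc1ccc(Cc2ccc3cc(NC(=O)c4ccc(OC)c(-c5cccc(OC)c5)c4)c(=O)oc3c2C)cc1`, not yet measured, carries the same kind of change relative to compound 3: methoxy in place of hydrogen on an aromatic carbon. The two places are not identical, since in compound 2 the entering methoxy sits ortho to a methoxy group and para to a large group, while in compound 4 it sits only para to a large group.

On the strength of the step from compound 1 to compound 2, compound 4 is expected to give a higher number than compound 3, an estimated 4.9-fold higher number from compound 3 to compound 4 (0.69 log units; beyond the scatter). The estimated value of compound 4 in this assay is 20000 nM, expected between 6000 nM and 100000 nM, with a real chance that only a limit is reported.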

Compound 4, half-maximal inhibitory concentration: > 100000 nM
Compound 4: a limit, no number (the forecaster's own chance of this, stated with the estimate: 20%); at least 5.0-fold (0.69 log units) between middle value and limit.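

In this assay compound 4 gives > 100000 nM, which is a limit of the assay and not a number. Methoxy in place of hydrogen on an aromatic carbon, here para to a large group, gave an at least 24-fold higher number from compound 3 to compound 4 (1.38 log units; beyond the scatter), so the two pairs shown agree in direction: the same change on two cores in this assay, an at least 6.7-fold higher number (0.82 log units; beyond the scatter) from compound 1 to compound 2 and an at least 24-fold higher number (1.38 log units; beyond the scatter) from compound 3 to compound 4; the limit leaves it open whether they differ. This shows that the direction of the change carried from one core to the other in these two pairs, but it does not show that the size carried over, or that the same would hold on any further core in the series, and both steps end at one limit: the limit of > 100000 nM in this assay, at which 2 of the 4 values shown sit.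

The compounds shown leave open what a group other than methoxy would do at this place on the benzyl ring, for instance a fluorine, an amine or a carboxylic acid, and whether any of these would keep the number close to that of the unsubstituted benzyl compound 3. They also leave open how far the numbers of compound 2 and compound 4 truly lie from those of their partners, and whether a longer chain such as ethoxy would give a result that could be read as a number.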